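Halogenated Aryl Sulfonamides and Cell Viability

The source may report more compounds than this note shows. Statements on the series, on what has been measured and on what is new or still open speak of the compounds shown alone.

Compound 1 `CC1CCN(C2CCN(S(=O)(=O)c3cccnc3)CC2)CC1` gives > 10000 nM in an ADME assay on HCT-116 cells (Homo sapiens) for cytotoxicity, read by CellTiter-Glo, with a stated time of 72 h (on this read-out lower numbers stand for stronger inhibition and higher numbers for weaker inhibition), a limit of the assay.
Compound 2 `CC1CCN(C2CCN(S(=O)(=O)c3cccc(Cl)c3)CC2)CC1` gives > 5000 nM in this assay, also a limit.
Compound 3 `CC1CCN(C2CCN(S(=O)(=O)c3ccc(Br)c(Cl)c3)CC2)CC1` gives > 5000 nM in this assay, again a limit.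

Compound 3 thus stands at a limit, and so do the other two values shown (the limit of > 10000 nM in this assay, at which 1 of the 3 values shown sits, (the limit of > 5000 nM in this assay, at which 2 of the 3 values shown sit)). The unmeasured compound 4 `CC1CCN(C2CCN(S(=O)(=O)c3ccc(Cl)cc3Cl)CC2)CC1` differs from compound 3 by 2,4-dichlorophenyl in place of 4-bromo-3-chlorophenyl on a sulfonyl sulfur. The measured steps a step that the two limits leave unreadable from compound 1 to compound 2, a step that the two limits leave unreadable from compound 1 to compound 3 and a step that the two limits leave unreadable from compound 2 to compound 3 bear on this change, yet none has a readable size; every value shown is a limit. No step beyond the scatter is therefore expected, and compound 4 is expected to sit at a limit too. The step that the limit leaves unreadable from compound 3 to compound 4 is estimated as no change beyond the scatter. Compound 4 is estimated at 9000 nM, in the range 3000 nM to 30000 nM.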

Compound 4, half-maximal inhibitory concentration: > 5000 nM
Compound 4: only a limit was reported; the forecaster's own chance of this, stated with the estimate: 85%; the middle value does not contradict the limit.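

Compound 4 gives > 5000 nM in this assay, a limit, so its steps from compound 1, compound 2 and compound 3 cannot be read. The compounds shown leave open whether any of the four reaches a half-maximal inhibitory concentration in this assay.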